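A Second Methoxy Group Across Two Related Cores

The source may hold more compounds than are shown below. What is called first, only, known or untested is meant among the compounds shown, and "the series" means these compounds.

Compound 1 `COc1ccc(C2CC(c3c(O)ccc4ccccc34)=NN2c2ccc(Cl)cc2)cc1` and compound 2 `COc1ccc(C2CC(c3c(O)ccc4ccccc34)=NN2c2ccc(Cl)cc2)c(OC)c1` share one core, and in a functional assay on HCT-116 cells (Homo sapiens) for cytotoxicity, read by crystal violet staining and colony formation, with a stated time of 7 days (on this read-out higher numbers stand for weaker inhibition and lower numbers for stronger inhibition), compound 1 gives 9800 nM while compound 2 gives 5400 nM. The change between them is methoxy in place of hydrogen on an aromatic carbon, and it produced a 1.8-fold lower number from compound 1 to compound 2 (0.26 log units; within the scatter). Compound 3 `COc1ccc(C2CC(c3ccc4ccccc4c3O)=NN2)c(OC)c1` is built on a different core; the difference between the two cores is not broken down here. In this assay compound 3 gives 8800 nM, a number that sits close to that of compound 1. Compound 4 `COc1cc(OC)c(C2CC(c3ccc4ccccc4c3O)=NN2)cc1OC` carries the change methoxy in place of hydrogen on an aromatic carbon relative to compound 3. This is the same kind of change as the one seen between the first two compounds, though the surroundings differ: in compound 2 the new group stands ortho to a large group and meta to a methoxy group, whereas in compound 4 it stands ortho to a methoxy group, meta to a large group and para to a methoxy group. Since the earlier step was a 1.8-fold lower number from compound 1 to compound 2 (0.26 log units; within the scatter), the expected step for compound 4 is a 1.4-fold lower number from compound 3 to compound 4 (0.13 log units; within the scatter). Compound 4 is therefore estimated at 6500 nM, with a likely range from 3000 nM to 14000 nM.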

Compound 4, half-maximal inhibitory concentration: 9000 nM
For compound 4 the middle estimate is 1.4-fold (0.14 log units) below the measured one, within the range that was stated.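

In this assay the added methoxy group gives a 1.0-fold higher number from compound 3 to compound 4 (0.01 log units; within the scatter), so on the core of compound 3 the step cannot be told apart from repeated measurement. Set beside the step on the core of compound 1, it does not differ from it beyond what repeated measurement allows: the same change on two cores in this assay, a 1.8-fold lower number (0.26 log units; within the scatter) from compound 1 to compound 2 and a 1.0-fold higher number (0.01 log units; within the scatter) from compound 3 to compound 4, 1.9-fold (0.27 log units) apart, within the scatter of two such steps. This means the data give no sign that the change behaves differently on the two cores, but they do not show that any effect carries over, as neither step is beyond the scatter and the new group stands in a different place in each pair.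

The compounds shown leave open whether an amine or a carboxylic acid in place of the added methoxy group would give a step beyond the scatter on either core. They also leave open how the methoxy change would read on the core of compound 1 in the place it takes in compound 4, ortho to a methoxy group and para to a methoxy group.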